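This account rests on a few compounds, and the source may have more. Where it says the series, first, only, none or still open, it means among the compounds named here.

Measured so far:
compound 1 `CC(=O)N(C)/N=N/c1nc(OCc2ccccc2)c2nc[nH]c2n1`, giving 58.3 h in an ADME assay for pharmacokinetics, in phosphate buffer; a higher number here means that the compound lasts longer, a lower number that the compound disappears faster
compound 2 `CN(/N=N/c1nc(OCc2ccccc2)c2nc[nH]c2n1)C(=O)c1ccccc1`, giving 38.3 h in this assay
compound 3 `CN(/N=N/c1nc(OCc2ccccc2)c2nc[nH]c2n1)C(=O)c1cccnc1`, giving 8.83 h in this assay

All three share one core and differ only in the group attached to a carbonyl carbon whose other neighbour is an amide-type nitrogen. Compound 3 holds the lowest of the three numbers: the steps of a 6.6-fold lower number from compound 1 to compound 3 (0.82 log units; beyond the scatter) and a 4.3-fold lower number from compound 2 to compound 3 (0.64 log units; beyond the scatter) both lie beyond the scatter, whereas the step of a 1.5-fold lower number from compound 1 to compound 2 (0.18 log units; within the scatter) stays within it.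

Compound 4 `CCOC(=O)N(C)/N=N/c1nc(OCc2ccccc2)c2nc[nH]c2n1` has not yet been measured. It differs from compound 3 in a single place: ethoxy in place of pyridin-3-yl on a carbonyl carbon. Among the measured compounds shown here, no measured step introduces an ethoxy group, so none bears on this change directly. What the measured steps do show is that the pyridin-3-yl group of compound 3 goes with the lowest number of the set, and compound 4 removes that group. A return toward the level of compounds 1 and 2 is therefore expected, since compound 1 gives 58.3 h and compound 2 gives 38.3 h with other groups on that carbon. The expected step is a 3.4-fold higher number from compound 3 to compound 4 (0.53 log units; beyond the scatter), with wide uncertainty. For compound 4 the estimated value is 30 h, within a range from 8 h to 110 h.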

Compound 4, half-life: 58.3 h
Estimate against measurement, compound 4: 1.9-fold (0.29 log units) below; the range from low to high includes it.
By their numbers in this assay, from the lowest: compound 3; then compounds 2, 1 and 4 (each within the scatter of the next).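

In this assay, the ethoxy group shows that this carbonyl carbon can carry a group attached through oxygen and stay level with the methyl and phenyl compounds: no change at the digits printed from compound 1 to compound 4 (within the scatter) and a 1.5-fold higher number from compound 2 to compound 4 (0.18 log units; within the scatter) both remain within the scatter. The pyridin-3-yl group now stands apart from three different groups, with a 6.6-fold higher number from compound 3 to compound 4 (0.82 log units; beyond the scatter), so among these four compounds the low number belongs to compound 3 alone. Methyl, phenyl and ethoxy cannot be told apart here, and the swap from (pyridin-3-yl)carbonyl to ethoxycarbonyl marks the only clear difference that involves compound 4.

Nothing in the data at hand explains why compound 3 alone gives the low number. Going by these compounds, it also remains open whether pyridin-2-yl, pyridin-4-yl, an amine on that carbonyl carbon or a longer chain such as butoxy would match compound 3 or instead stay with compounds 1, 2 and 4.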